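The source may hold more compounds than are shown below. What is called first, only, known or untested is meant among the compounds shown, and "the series" means these compounds.

Measured in a functional assay on A549 cells (Homo sapiens) for inhibition, read by MTT assay, with a stated time of 72 h (on this read-out lower numbers stand for stronger inhibition and higher numbers for weaker inhibition), so far:
- Compound 1 `COc1cc(O)c(CC=C(C)C)c(O)c1C(=O)/C=C/c1cccc([N+](=O)[O-])c1` gives 15000 nM
- Compound 2 `COc1cc(OC)c(C(=O)/C=C/c2ccccc2OC)c(OC)c1` gives 19800 nM
- Compound 3 `COc1cc(OC)c(C(=O)/C=C/c2ccc([N+](=O)[O-])cc2)c(OC)c1` gives 7100 nM

Compound 3 has the lowest of the three numbers, and the gaps up to compound 1 and compound 2 both lie beyond the scatter. Compound 4 `COc1cc(OC)c(C(=O)/C=C/c2ccc(Cl)cc2)c(OC)c1` has not yet been measured. It keeps the core of compound 3 but has chloro in place of nitro on an aromatic carbon, para to a large group (chloro in place of nitro on an aromatic carbon).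

Within the data shown here, no two measured compounds differ in one place only, so the data give no direct guide to this change. Compound 2 has no nitro group and gives 19800 nM in this assay, whereas compound 1 has one and gives 15000 nM on the same read-out, so the three values do not tie nitro to a low number. A small rise in this assay is expected, probably within the scatter. The estimated change is a 1.5-fold higher number from compound 3 to compound 4 (0.19 log units; within the scatter) (an expectation only). For compound 4 the expected value is 11000 nM (estimated range 4500 nM to 26000 nM).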

Compound 4, half-maximal inhibitory concentration: 13300 nM
Compound 4: middle estimate off by 1.2-fold (0.08 log units), on the low side, and the stated range covers the measured number.
By their numbers in this assay, from the lowest: compounds 3, 4, 1 and 2 (each within the scatter of the next, the first and the last beyond it).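

In this assay, among these compounds, chloro in place of nitro on an aromatic carbon, para to a large group, gives a 1.9-fold higher number from compound 3 to compound 4 (0.27 log units; within the scatter) and is the first direct reading of this change, which shows that a low number at this place does not clearly depend on nitro. The other step, 4-chlorophenyl in place of 2-methoxyphenyl, gives a 1.5-fold lower number from compound 2 to compound 4 (0.17 log units; within the scatter) and so does not clearly separate these two compounds either. No supporting evidence is available to explain either step.

Going by these compounds, it remains open whether another group on this aromatic carbon, such as an amine or a carboxylic acid, would shift the number beyond the scatter. On these data alone, it is also open whether chloro in place of nitro would give a step of similar size on the core of compound 1.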